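Swapping the Ring on the Amine of a Shared Core

The compounds below may be only part of what the source reports. "The series", "measured", "known", "first", "only" and "open" are said of these compounds alone.

Compound 1 `Cc1ccc(NC2=CC(=O)c3nc4n(c3C2=O)[C@H]2OC[C@@H](O)[C@H]2OC4)cc1C` carries a 3,4-dimethylphenyl group on an amine nitrogen. For the measured compounds named here, in a functional assay on MCF7 cells (Homo sapiens) for inhibition, read by sulforhodamine B assay (a lower number here means a stronger inhibitor, a higher number a weaker inhibitor), compound 1 gives 2080 nM, the only numerical value among the compounds here. Compound 2 `O=C1C(NC2CCCCC2)=CC(=O)c2c1nc1n2[C@H]2OC[C@@H](O)[C@H]2OC1` has a cyclohexyl group in its place. In this assay compound 2 gives > 16000 nM, which is a limit of the assay and not a number. This is the limit of > 16000 nM in this assay, at which 1 of the 2 values shown sits. Compound 3 `CCOc1ccccc1NC1=CC(=O)c2nc3n(c2C1=O)[C@H]1OC[C@@H](O)[C@H]1OC3` is not yet measured and differs from compound 1 in one place: 2-ethoxyphenyl in place of 3,4-dimethylphenyl on an amine nitrogen. Going by the values given here, no measured step of this kind exists here, so only a modest shift in this assay is expected, likely within the scatter. Compound 3 is estimated at 3000 nM, with a range of 1000 nM to 10000 nM. The expected step is a 1.4-fold higher number from compound 1 to compound 3 (0.16 log units; within the scatter).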

Compound 3, half-maximal inhibitory concentration: > 4000 nM
Compound 3 was reported as a limit; the forecaster's own chance of this, stated with the estimate: 15%; middle value at least 1.3-fold (0.12 log units) from the limit.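

In this assay compound 3 gives > 4000 nM, which is a limit of the assay and not a number. From the compounds shown here alone, the change gives an at least 1.9-fold higher number from compound 1 to compound 3 (0.28 log units; that floor lies within the scatter), so the true size of this step remains unknown. Compound 3 keeps an aromatic ring on the amine nitrogen, unlike compound 2, yet it also ends at a limit, so an aromatic ring there does not by itself ensure a measurable value.

The compounds shown leave open how far compound 3 truly lies from compound 1. They also leave open how a chlorine atom or a carboxylic acid on that aromatic ring would read.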